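Swapping a dimethoxy pattern on a chloro analogue

The source may report more compounds than this note shows. Statements on the series, on what has been measured and on what is new or still open speak of the compounds shown alone.

Compound 1 `COc1ccc(Cn2cc(CNC(=O)c3cn(-c4ccccc4)nc3-c3ccc(F)cc3)nn2)cc1OC` is the starting point; in a functional assay on HeLa cells (Homo sapiens) for antiproliferative activity, read by sulforhodamine B assay, with a stated time of 48 h (on this read-out higher numbers stand for weaker inhibition of growth and lower numbers for stronger inhibition of growth), compound 1 gives 200 nM. Compound 2 `COc1cc(Cn2cc(CNC(=O)c3cn(-c4ccccc4)nc3-c3ccc(F)cc3)nn2)cc(OC)c1` carries one change, (3,5-dimethoxyphenyl in place of 3,4-dimethoxyphenyl on a saturated chain carbon bound to an aromatic nitrogen), and shows a 1.8-fold higher number from compound 1 to compound 2 (0.26 log units; within the scatter); compound 2 gives 360 nM. Compound 3 `COc1ccc(Cn2cc(CNC(=O)c3cn(-c4ccccc4)nc3-c3ccc(Cl)cc3)nn2)cc1OC` differs from compound 1 only by chloro in place of fluoro on an aromatic carbon, giving no change at the digits printed from compound 1 to compound 3 (within the scatter); compound 3 gives 200 nM. Compound 4 `COc1cc(Cn2cc(CNC(=O)c3cn(-c4ccccc4)nc3-c3ccc(Cl)cc3)nn2)cc(OC)c1`, not yet measured, differs from compound 3 by 3,5-dimethoxyphenyl in place of 3,4-dimethoxyphenyl on a saturated chain carbon bound to an aromatic nitrogen, the same change as from compound 1 to compound 2, made on a core that differs by chloro in place of fluoro on an aromatic carbon. The step from compound 3 to compound 4 is expected to be a 1.8-fold higher number from compound 3 to compound 4 (0.26 log units; within the scatter), close to the earlier one, because a 1.8-fold higher number from compound 1 to compound 2 (0.26 log units; within the scatter) shows how this change behaved. Compound 4 is therefore estimated at 360 nM, between 180 nM and 720 nM.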

Compound 4, concentration for 50% growth inhibition: 730 nM
Beside the measured number, compound 4's estimate is 2.0-fold (0.31 log units) below it; the measured number lies above the stated range.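

In this assay, 3,5-dimethoxyphenyl in place of 3,4-dimethoxyphenyl gives a 3.7-fold higher number from compound 3 to compound 4 (0.56 log units; beyond the scatter), and chloro in place of fluoro, with 3,5-dimethoxyphenyl present, gives a 2.0-fold higher number from compound 2 to compound 4 (0.31 log units; beyond the scatter). The dimethoxy change raises the number on both cores, and its size cannot be told apart between them, so it carries over within this small set: the same change on two cores in this assay, a 1.8-fold higher number (0.26 log units; within the scatter) from compound 1 to compound 2 and a 3.7-fold higher number (0.56 log units; beyond the scatter) from compound 3 to compound 4, 2.0-fold (0.31 log units) apart, within the scatter of two such steps. The halogen change likewise gives no evidence that its effect depends on the dimethoxy pattern, though these four compounds cannot prove that the two changes act independently: the same change on two cores in this assay, no change at the digits printed (within the scatter) from compound 1 to compound 3 and a 2.0-fold higher number (0.31 log units; beyond the scatter) from compound 2 to compound 4, 2.0-fold (0.31 log units) apart, within the scatter of two such steps.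

The compounds shown leave open whether the dimethoxy change would carry over to a core with methyl or trifluoromethyl in place of the halogen. They also leave open how a 3,4,5-trimethoxyphenyl group would compare.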